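The source may report more compounds than this note shows. Statements on the series, on what has been measured and on what is new or still open speak of the compounds shown alone.

Working notes on the series.

Compound 2 `CCCCCCCCCCc1ccc(-c2noc(CC(CN)OC(C)=O)n2)cc1` gives 0% in an assay on HeLa cells for inhibition of sphingosine-1-phosphate transporter SPNS2 (Mus musculus), read by LC-MS, tested at 2 uM (a lower number here means less inhibition, a higher number more inhibition at the concentration tested (going by the name of the read-out)), and stands lowest of the two numbers in hand; its nearest neighbour is compound 1 `CCCCCCCCCCc1ccc(-c2noc(C3CCNCC3)n2)cc1`, which gives 66% in this assay. Within the data shown here, the one measured step, a number 66 percentage points lower from compound 1 to compound 2 (beyond the scatter), came with a group of 8 heavy atoms (5 carbon, 1 nitrogen, 2 oxygen; no ring) in place of a group of 6 heavy atoms (5 carbon, 1 nitrogen; one six-membered non-aromatic ring with 1 hetero atom), on an aromatic carbon.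

Compound 3 `CCCCCCCCCCc1ccc(-c2noc([C@@H](N)CCCCN)n2)cc1` is not yet measured. Against compound 2 it carries a group of 7 heavy atoms (5 carbon, 2 nitrogen; no ring) in place of a group of 8 heavy atoms (5 carbon, 1 nitrogen, 2 oxygen; no ring), on an aromatic carbon. The step from compound 1 to compound 2 is the only one that bears on this, and it was large; compound 3 brings back a group with a nitrogen count at least that of compound 1, though without the ring, so some of the lost inhibition is expected to return. In this assay compound 3 is estimated at 40%, within 10% to 75%, which means an expected step of a number 40 percentage points higher from compound 2 to compound 3 (beyond the scatter).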

Compound 3, a percentage reported as inhibition, at one concentration (the size of the read-out at that concentration, not a potency): 43%
The estimate for compound 3 lay 3 percentage points below the measured number; low and high end bracket the measured number.
By their numbers in this assay, from the lowest: compound 2; then compound 3; then compound 1.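

In this assay, the step to the open-chain 1,5-diaminopentyl group is a number 43 percentage points higher from compound 2 to compound 3 (beyond the scatter), so at this aromatic carbon of the five-membered aromatic ring, the loss seen with compound 2 does not follow from the absence of a ring alone. The ring still counts for something in this pair: 1,5-diaminopentyl in place of piperidin-4-yl gives a number 23 percentage points lower from compound 1 to compound 3 (beyond the scatter), a modest step against the large one from compound 2, so the chain recovers much of the inhibition without matching the piperidin-4-yl group. Nothing at hand gives a reason for either step.

As far as these compounds go, it remains open which of the two amines of the 1,5-diaminopentyl group carries the inhibition in this assay, and whether the defined stereocentre matters, since the group changes as a whole across these compounds. A chain with a single terminal amine, a shorter diamine chain, the opposite stereocentre or a carboxylic acid in place of the terminal amine would separate these features.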